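A Third Fluorine on the Ring-Amine Substituent

The source may hold more compounds than are shown below. What is called first, only, known or untested is meant among the compounds shown, and "the series" means these compounds.

Three compounds share a core and differ only in the group on an amine nitrogen in a ring. Compound 1 `COc1ccc(N2CCN(Cc3csc(N)c3C(=O)c3ccc(Cl)cc3)CC2)cc1` carries a 4-methoxyphenyl there; in an assay on CHO cells for displacement of a labelled ligand from adenosine receptor A1 (Homo sapiens), read by scintillation counting, with a stated time of 120 min, tested at 10 uM (a higher number here means more inhibition at the concentration tested (going by the name of the read-out), a lower number less inhibition), compound 1 gives 0%. Compound 2 `Nc1scc(CN2CCN(c3c(F)cccc3F)CC2)c1C(=O)c1ccc(Cl)cc1` has a 2,6-difluorophenyl and in this assay compound 2 gives 1%. Compound 3 `Nc1scc(CN2CCN(c3cc(F)ccc3F)CC2)c1C(=O)c1ccc(Cl)cc1` has a 2,5-difluorophenyl and in this assay compound 3 gives 1%. Compound 3 thus stands level with compound 2 at the digits printed, the two together the highest of the three numbers, with compound 1 nearest to them and at the same time furthest, a number 1 percentage points higher from compound 1 to compound 3 (within the scatter).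

Compound 4 `Nc1scc(CN2CCN(c3c(F)cc(F)cc3F)CC2)c1C(=O)c1ccc(Cl)cc1` differs from compound 3 by 2,4,6-trifluorophenyl in place of 2,5-difluorophenyl on an amine nitrogen in a ring. Going by the values given here, the steps that bear on this change are small: a number 1 percentage points higher from compound 1 to compound 2 (within the scatter), a number 1 percentage points higher from compound 1 to compound 3 (within the scatter), and no change at the digits printed from compound 2 to compound 3 (within the scatter). Each exchange of the group on the ring amine, whether a methoxy for two fluorines or a move of one fluorine, left the inhibition unchanged within the scatter. A further fluorine on that ring is therefore expected to leave this assay where it is, with no step beyond the scatter, no change at the digits printed from compound 3 to compound 4 (within the scatter). For compound 4 the estimate in this assay is 1%, with a range from -6% to 9%.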

Compound 4, a percentage reported as inhibition, at one concentration (the size of the read-out at that concentration, not a potency): 0%
Compound 4: the middle estimate sits 1 percentage points above what was measured, and the stated range covers the measured number.
By their numbers in this assay, from the lowest: compounds 1, 4, 2 and 3 (each within the scatter of the next).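

In this assay the 2,4,6-trifluorophenyl on the amine nitrogen in a ring gives a number 1 percentage points lower from compound 3 to compound 4 (within the scatter) and, read as fluoro in place of hydrogen on an aromatic carbon, a number 1 percentage points lower from compound 2 to compound 4 (within the scatter); a change in the number of fluorines therefore joins the move of a fluorine among the exchanges that stay within the scatter. Against the 4-methoxyphenyl the same group gives no change at the digits printed from compound 1 to compound 4 (within the scatter) and all four compounds lie within the scatter of one another, so no substituted phenyl shown at this position separates from the rest. No evidence at hand accounts for this flat result.

Every group shown on this nitrogen is a substituted phenyl, so it remains open whether a pyridine ring, a saturated ring such as cyclohexyl, or a longer chain ending in an amine or a carboxylic acid would move the inhibition from its present level. The shared core is also the same in all four compounds, which leaves open whether a change elsewhere on it would raise the read-out at all.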